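Swapping the Amine Tail and Lung Half-Life

A few compounds are considered here, and "the series" means these few. Any claim that something is new, unique, unknown or untested is made for them only; others in the source may bear on it.

Of the compounds shown here, three sharing one core have been measured in an ADME assay on the whole organism (lung, Rattus norvegicus) for metabolic stability, read by LC-MS; a higher number here means that the compound lasts longer, a lower number that the compound disappears faster. Compound 1, `Cc1csc2cc([C@H](C)Nc3ncnc(N)c3C#N)c(-c3cccc(CN4CCC(CN(C)Cc5ccccn5)CC4)c3)c(=O)n12`, gives 10.9 h. Compound 3, `Cc1csc2cc([C@H](C)Nc3ncnc(N)c3C#N)c(-c3cccc(CN(C)CCCN(C)Cc4ccc(Cl)cc4)c3)c(=O)n12`, gives 13 h; among the two numbers shown, compound 1 is the lower, but its gap to compound 3 lies within the scatter, so the two cannot be told apart. Compound 2, `Cc1csc2cc([C@H](C)Nc3ncnc(N)c3C#N)c(-c3ccccc3)c(=O)n12`, which lacks any side chain on the aryl group, reaches only the limit of < 0.1 h in this assay; that is a limit of the assay and not a number (the limit of < 0.1 h in this assay, at which 1 of the 3 values shown sits).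

The step now followed leads from compound 1 to compound 4, `Cc1csc2cc([C@H](C)Nc3ncnc(N)c3C#N)c(-c3cccc(CN4CCC(N(C)CCC(F)(F)F)CC4)c3)c(=O)n12`. The change is methyl(3,3,3-trifluoropropyl)amino in place of (methyl((pyridin-2-yl)methyl)amino)methyl on a saturated ring carbon. No measured pair shows this exact change, so the expected size of the step comes from the shown values alone: compound 1 at 10.9 h and compound 3 at 13 h both carry an amine-bearing chain on the aryl group, and compound 4 keeps such a chain. The half-life of compound 4 is therefore expected to stay within a modest step, a 1.4-fold lower number from compound 1 to compound 4 (0.13 log units; within the scatter). The estimate for compound 4 is 8 h, between 2.5 h and 25 h.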

Compound 4, half-life in the lung assay: 8.7 h
For compound 4 the middle estimate is 1.1-fold (0.04 log units) below the measured one; the measured number falls inside the stated range.
By their numbers in the lung assay, from the lowest: compounds 4, 1 and 3 (each within the scatter of the next). At a limit, below all of these: compound 2.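

Putting methyl(3,3,3-trifluoropropyl)amino in place of (methyl((pyridin-2-yl)methyl)amino)methyl on this saturated ring carbon removes the aromatic ring from the tail, yet the half-life in the lung assay gives no readable difference: a 1.3-fold lower number from compound 1 to compound 4 (0.10 log units; within the scatter). In a physicochemical assay for lipophilicity (on this read-out lower numbers stand for lower lipophilicity and higher numbers for higher lipophilicity), compound 1 gives 2 and compound 4 gives 1.1, which is a number 0.90 log units lower from compound 1 to compound 4 (beyond the scatter). This single change therefore separates the two read-outs, shifting the distribution coefficient beyond the scatter while the half-life stays within it.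

The change swaps the pyridine ring for a fluorinated chain in one step, so the compounds shown cannot say which part of it accounts for the shift in the physicochemical assay. A plain propyl group on the same amine would help to separate the two, and a carboxylic acid on the tail would test how far the half-life in the lung assay tolerates a different kind of group.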